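Shifting the methylsulfanyl group on the phenyl ring

The source may hold more compounds than are shown below. What is called first, only, known or untested is meant among the compounds shown, and "the series" means these compounds.

In an assay for inhibition of Fatty-acid amide hydrolase 1 (Rattus norvegicus) (a higher number here means a weaker inhibitor, a lower number a stronger inhibitor), compound 3 `CSc1ccccc1CCCCCCC(=O)c1ncc(-c2ccccn2)o1` gives 3.3 nM, the higher of the two numbers in hand; compound 2 `O=C(CCCCCCc1ccccc1Cl)c1ncc(-c2ccccn2)o1` gives 1.9 nM, and the step of a 1.7-fold higher number from compound 2 to compound 3 (0.24 log units; within the scatter) lies within the scatter. Compound 1 `O=C(O)c1ccc(CCCCCCC(=O)c2ncc(-c3ccccn3)o2)cc1` gives only a limit in this assay, > 600 nM. Compound 4 `CSc1ccc(CCCCCCC(=O)c2ncc(-c3ccccn3)o2)cc1` differs from compound 3 by 4-(methylsulfanyl)phenyl in place of 2-(methylsulfanyl)phenyl on a saturated chain carbon, six bonds along the chain from a carbonyl carbon. For the measured compounds named here, the steps of an at least 180-fold lower number from compound 1 to compound 3 (2.25 log units; beyond the scatter) and an at least 310-fold lower number from compound 1 to compound 2 (2.49 log units; beyond the scatter) both start from a 4-carboxyphenyl and change group and place at once, so no measured step isolates the place of the methylsulfanyl group alone. A small step of a 1.8-fold higher number from compound 3 to compound 4 (0.26 log units; within the scatter) is therefore expected in this assay, not clearly beyond the scatter. Compound 4 is estimated at 6 nM, between 2 nM and 30 nM.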

Compound 4, inhibition constant: 2.5 nM
Compound 4: the middle estimate sits 2.4-fold (0.38 log units) above what was measured, and the stated range covers the measured number.
By their numbers in this assay, from the lowest: compounds 2, 4 and 3 (each within the scatter of the next). At a limit, above all of these: compound 1.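

The step of a 1.3-fold lower number from compound 3 to compound 4 (0.12 log units; within the scatter) and the step of a 1.3-fold higher number from compound 2 to compound 4 (0.12 log units; within the scatter) show that in this assay neither the place of the methylsulfanyl group on the phenyl ring nor the change from 2-chlorophenyl separates these compounds. For the compounds shown here, the step of an at least 240-fold lower number from compound 1 to compound 4 (2.38 log units; beyond the scatter) is the first to isolate a single group, methylsulfanyl in place of carboxy on the same aromatic carbon. Its starting value, for compound 1, is a limit and not a number: the limit of > 600 nM in this assay, at which 1 of the 4 values shown sits.

The compounds shown leave open how an amine on the phenyl ring would read in this assay. They also leave open whether a carboxylic acid in the 2-position or a longer chain would change the number.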